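Carbamate ester swap on a shared core: efficacy notes

A few compounds are considered here, and "the series" means these few. Any claim that something is new, unique, unknown or untested is made for them only; others in the source may bear on it.

Measured compounds:
compound 1 `CC1(COC(=O)N2CC3COCC(C2)C3Oc2ncnc(Nc3ccc(C#N)cc3Cl)c2F)COC1` gives 41%
compound 2 `CC1(OC(=O)N2CC3COCC(C2)C3Oc2ncnc(Oc3ccccc3F)c2F)CC1` gives 114%

In a functional assay on HEK293 cells for agonist activity at Glucose-dependent insulinotropic receptor (Homo sapiens), read by cAMP accumulation, with a stated time of 30 min (on this read-out higher numbers stand for larger maximal responses and lower numbers for smaller maximal responses), compound 1 gives 41%, the lowest of the two numbers. Compound 2 gives 114%, far higher and beyond the scatter. Within the data shown here, the two compounds differ in more than one place, so no single step is drawn between them; only the two values themselves are known.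

Compound 3 `CC1(OC(=O)N2CC3COCC(C2)C3Oc2ncnc(Nc3ccc(C#N)cc3Cl)c2F)CCC1` differs from compound 1 in one place: 1-methylcyclobutyl in place of (3-methyloxetan-3-yl)methyl on an oxygen next to a carbonyl group. Among the measured compounds shown here, the group that enters is the one carried by compound 2.

The step from compound 1 to compound 3 is expected to go upward and to exceed the scatter, since compound 2 reaches 114% with the same entering group, though its other difference from compound 1 leaves the size uncertain; the expected step is a number 24 percentage points higher from compound 1 to compound 3 (beyond the scatter). Compound 3 is estimated at 65%, with a range of 35% to 100%.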

Compound 3, largest response reached (reported as percent of maximum), in percent of the reference or control that the assay uses: 59%
Estimate against measurement, compound 3: 6 percentage points above, and the stated range covers the measured number.
By their numbers in this assay, from the lowest: compound 1; then compound 3; then compound 2.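

In this assay, the ester group alone moves the maximal response: with the rest of compound 1 held, 1-methylcyclobutyl in place of (3-methyloxetan-3-yl)methyl on an oxygen next to a carbonyl group gives a number 18 percentage points higher from compound 1 to compound 3 (beyond the scatter) on this first single-place step in the series. The same entering group does not by itself bring the anilino series to the level of the aryl ether, since compound 3 keeps the nitrile-bearing aryl amine and stays far from compound 2 at 114% in the printed values. Nothing at hand explains the step.

The change alters the ring and the attachment at once, so the two remain unseparated; a 3-methyloxetan-3-yl group on the same oxygen would divide them. Going by these compounds, how a tert-butyl group or a longer chain behaves there also stays open.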